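This account rests on a few compounds, and the source may have more. Where it says the series, first, only, none or still open, it means among the compounds named here.

Measured in a functional assay on HCT-116 cells (Homo sapiens) for antiproliferative activity, read by CCK-8 assay, with a stated time of 72 h; a lower number here means a stronger inhibitor, a higher number a weaker inhibitor:
- compound 1 `CCc1ccc(SCc2ccc(/C=C/C(=O)Nc3ccccc3N)cc2)cc1` gives "not determined" (no result reported)
- compound 2 `Nc1ccccc1NC(=O)c1ccc(CSc2cccc(F)c2)cc1` gives 2870 nM

For the measured compounds named here, compound 2 holds the only number, so it has no rank against any other compound. Compound 3 `Nc1ccccc1NC(=O)c1ccc(CSc2ccc(F)cc2)cc1` is the next to be measured, and it differs from compound 2 at a single place: 4-fluorophenyl in place of 3-fluorophenyl on a sulfur. Going by the values given here, the series holds no measured step for this change, so no shift beyond the usual scatter in this assay is expected, and no direction is favoured. The expected step of a 1.1-fold lower number from compound 2 to compound 3 (0.06 log units; within the scatter) is small. Compound 3 is estimated at 2500 nM, with an expected range of 1000 nM to 6000 nM.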

Compound 3, half-maximal inhibitory concentration: 4010 nM
Compound 3: middle estimate off by 1.6-fold (0.21 log units), on the low side; measured number inside the range.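

In this assay, 4-fluorophenyl in place of 3-fluorophenyl on a sulfur gives a 1.4-fold higher number from compound 2 to compound 3 (0.15 log units; within the scatter) within the scatter, so this first step at the position does not separate the two fluorophenyl groups. No supporting data bear on this step. Open, on these data alone, is whether any group on the sulfur can shift the number beyond the scatter. An unsubstituted phenyl, a 2-fluorophenyl, or a phenyl carrying an amine or a carboxylic acid would test this, and a longer chain between the sulfur and the core remains a separate question.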